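Compound 3 to compound 4: a step behind limits

The compounds below may be only part of what the source reports. "The series", "measured", "known", "first", "only" and "open" are said of these compounds alone.

Measured in an ADME assay on HEK293 cells (Homo sapiens) for cytotoxicity, read by resazurin assay, with a stated time of 72 h (on this read-out higher numbers stand for lower toxicity in this test and lower numbers for higher toxicity in this test), each value a limit and not a number:
- compound 1 `COc1cccc(CNC(=O)c2nc3ccc(F)c(OCCc4ccc(N)cc4)c3c(=O)[nH]2)c1`: > 20000 nM
- compound 2 `O=C(O)c1ccc(CCOc2c(F)ccc3nc(C(=O)NCc4cccc(OCC5CC5)c4)[nH]c(=O)c23)cc1`: > 20000 nM
- compound 3 `O=C(O)c1ccc(CCOc2c(F)ccc3nc(C(=O)NCc4cccc(C5CC5)c4)[nH]c(=O)c23)cc1`: > 20000 nM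

Compound 3 has no number, only the limit > 20000 nM. Among the compounds with values here, the series so far shows (the limit of > 20000 nM in this assay, at which 3 of the 3 values shown sit). Compound 4 `CCc1cccc(CN(C)C(=O)c2nc3ccc(F)c(OCCc4ccc(C(=O)O)cc4)c3c(=O)[nH]2)c1` has (3-ethylbenzyl)(methyl)amino in place of (3-cyclopropylbenzyl)amino on a carbonyl carbon. Within the data shown here, the one measured step is a step that the two limits leave unreadable from compound 2 to compound 3, so it offers no size to carry over, and it lies at a different place. In this assay no step beyond the scatter is expected, and a further limit is the likeliest report. The estimated step is a step that the limit leaves unreadable from compound 3 to compound 4. That expectation rests on (the limit of > 20000 nM in this assay, at which 3 of the 3 values shown sit). For compound 4 the estimate is 25000 nM, with an expected range of 12000 nM to 50000 nM.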

Compound 4, half-maximal cytotoxic concentration: > 20000 nM
Compound 4: no number, only a limit; the forecaster's own chance of this, stated with the estimate: 85%; the middle value lies beyond the limit too.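

Within the data shown here, compound 3 and compound 4 each carry only a limit in this assay, so no step between them can be read. The compounds shown leave open how any of them would compare on an actual number in this assay.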